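This account rests on a few compounds, and the source may have more. Where it says the series, first, only, none or still open, it means among the compounds named here.

Of the compounds shown here, three from this series have been measured in a functional assay for antagonist activity at transient receptor potential cation channel subfamily V member 1 (Homo sapiens), read by FLIPR and calcium flux; a higher number here means a weaker inhibitor, a lower number a stronger inhibitor. Compound 1 `O=C(Nc1cccc2[nH]ccc12)C1CCN(c2cccc(C(F)(F)F)c2)CC1` gives 230 nM. Compound 2 `CC(=O)N1CCc2cccc(NC(=O)C3CCN(c4cccc(C(F)(F)F)c4)CC3)c21`, which carries a different core, gives 5610 nM. Compound 3 `O=C1COc2ccc(NC(=O)C3CCN(c4cccc(Br)c4)CC3)cc2N1` gives 330 nM, the second highest of the three numbers: its nearest neighbour is compound 1, whose number lies within the scatter of it, while compound 2 is the furthest, with a number beyond the scatter above it. Compound 1 and compound 3 are thus indistinguishable on these data, and only compound 2 is clearly weaker than the other two.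

Compound 4 `O=C1COc2ccc(NC(=O)C3CCN(c4ccccc4Cl)CC3)cc2N1` has not yet been measured. It differs from compound 3 in one place: 2-chlorophenyl in place of 3-bromophenyl on an amine nitrogen in a ring. Going by the values given here, no step between measured compounds speaks directly to this exchange, since no pair in the set differs in a single place, so the expectation rests on the general shape of the set rather than on a counted step. The step from compound 3 to compound 4 is expected to be a moderate loss, beyond the scatter, in the direction of a weaker inhibitor, estimated at a 3.6-fold higher number from compound 3 to compound 4 (0.56 log units; beyond the scatter). On that basis compound 4 is expected to give about 1200 nM in this assay, with a plausible range from 400 nM to 4000 nM.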

Compound 4, half-maximal inhibitory concentration: 220 nM
The estimate for compound 4 lay 5.5-fold (0.74 log units) above the measured number; measured number outside the range, below it.
By their numbers in this assay, from the lowest: compounds 4, 1 and 3 (each within the scatter of the next); then compound 2.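

In this assay, putting 2-chlorophenyl in place of 3-bromophenyl on the amine nitrogen in the ring gives a 1.5-fold lower number from compound 3 to compound 4 (0.18 log units; within the scatter), which lies within the scatter, so the two groups cannot be told apart at this position on the shared core. Going by these compounds alone, this is the first step in the set that differs in one place only, and it shows that the halogen and its place on the phenyl ring can change together with no measurable effect on the number, although a single step cannot show whether either change alone would also be silent. Nothing measured here bears on why this step is so small.

From the compounds shown here alone, the exchange alters the element and its place at once, so it remains open how each would act alone, a question that 3-chlorophenyl or 2-bromophenyl on the same core could separate. Going by these compounds, it also remains open how far this position stays open to change, for example with an unsubstituted phenyl, a 3-trifluoromethylphenyl on this core, or a pyridine ring in place of the phenyl.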